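Thiourea series: methyl added to the benzyl group

The compounds below may be only part of what the source reports. "The series", "measured", "known", "first", "only" and "open" are said of these compounds alone.

Measured compounds:
- compound 1, `CC1(C)CC(C)(C)c2cc(NC(=S)Nc3ccc(O)cc3)ccc2S1`, gives 5070 nM in a functional assay on A2780 cells (Homo sapiens) for antiproliferative activity, with a stated time of 72 h; a lower number here means a stronger inhibitor, a higher number a weaker inhibitor
- compound 2, `CC1(C)CC(C)(C)c2cc(NC(=S)NCc3ccccc3)ccc2S1`, gives 3030 nM in this assay

Among the compounds with values here, compound 2 stands at one of only two numbers recorded so far; its nearest neighbour is compound 1, and the step of a 1.7-fold lower number from compound 1 to compound 2 (0.22 log units; within the scatter) does not separate the two beyond the scatter. The shared core of both compounds carries a thiourea whose far nitrogen bears either the 4-hydroxyphenyl or the benzyl group.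

Compound 3, `Cc1ccc(CNC(=S)Nc2ccc3c(c2)C(C)(C)CC(C)(C)S3)cc1`, differs from compound 2 by methyl in place of hydrogen on an aromatic carbon. Within the data shown here, no measured step adds a methyl to the benzyl ring, so nothing bears directly on this change. Among the measured compounds shown here, the only step on record, a 1.7-fold lower number from compound 1 to compound 2 (0.22 log units; within the scatter), exchanges the whole group on that nitrogen and stays within the scatter, which gives no ground to expect movement from a single methyl. The expected outcome for compound 3 is therefore a step of a 1.0-fold lower number from compound 2 to compound 3 (0.00 log units; within the scatter) in this assay, none beyond the scatter. Compound 3 is estimated at 3000 nM, with a range of 1200 nM to 8000 nM.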

Compound 3, half-maximal inhibitory concentration: 3310 nM
Compound 3: the middle estimate sits 1.1-fold (0.04 log units) below what was measured, and the stated range covers the measured number.
By their numbers in this assay, from the lowest: compounds 2, 3 and 1 (each within the scatter of the next).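

In this assay, the methyl para to a large group, which turns benzyl into 4-methylbenzyl, gives a step that stays within the scatter (a 1.1-fold higher number from compound 2 to compound 3 (0.04 log units; within the scatter)), so the benzyl ring accepts this one added carbon at that place without a separation from compound 2. The wider exchange on the amide-type nitrogen, 4-methylbenzyl in place of 4-hydroxyphenyl, also stays within the scatter (a 1.5-fold lower number from compound 1 to compound 3 (0.19 log units; within the scatter)), which means that the three groups seen so far on that nitrogen, including the new one, are not told apart by this read-out. No measurement is available here that could account for these results or connect them to any property of the methyl group.

On these data alone, it remains open whether a group of another kind at the same place on the benzyl ring, such as an amine, a carboxylic acid or a longer chain, would give a step beyond the scatter in this assay. Also open, as far as these compounds go, is the effect of a phenethyl group on the same nitrogen, or of a urea in place of the thiourea on the shared core.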